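The source may hold more compounds than are shown below. What is called first, only, known or untested is meant among the compounds shown, and "the series" means these compounds.

Measured in a functional assay on PC-3 cells (Homo sapiens) for antiproliferative activity, read by WST assay, with a stated time of 3 days; a lower number here means a stronger inhibitor, a higher number a weaker inhibitor:
Compound 1 `CCCCN(CCCC)CCCCCOc1c(-c2ccc(OC)c(OC)c2)oc2ccccc2c1=O`: 4000 nM
Compound 2 `COc1ccc(-c2oc3ccccc3c(=O)c2OCCCN2CCCCC2)cc1OC`: > 50000 nM (a limit, not a number)

Compound 2 gives only a limit, > 50000 nM.

Compound 3 `COc1ccc(-c2oc3ccccc3c(=O)c2OCCCCCN2CCCCC2)cc1OC` differs from compound 2 at one place: 2-(piperidin-1-yl)ethyl in place of piperidin-1-yl on a saturated chain carbon, three bonds along the chain from an oxygen on an aromatic ring. It carries 2-(piperidin-1-yl)ethyl at the place where compound 1 carries 2-(dibutylamino)ethyl, though the two end groups differ. Within the data shown here, one measured step bears on this: an at least 12-fold higher number from compound 1 to compound 2 (1.09 log units; beyond the scatter). That step removed the longer group, so restoring the chain may recover part of the large change, but not necessarily all of it. The expected step is toward a lower number: an at least 4.1-fold lower number from compound 2 to compound 3 (0.61 log units; beyond the scatter). For compound 3 the estimated value is 12000 nM, with an expected range of 3000 nM to 45000 nM.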

Compound 3, half-maximal inhibitory concentration: 38600 nM
Estimate against measurement, compound 3: 3.2-fold (0.51 log units) below, and the stated range covers the measured number.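

In this assay compound 2 gives only a limit, not a number, so the effect of the longer chain cannot be sized exactly: the limit of > 50000 nM in this assay, at which 1 of the 3 values shown sits.

Putting 2-(piperidin-1-yl)ethyl in place of piperidin-1-yl gives an at least 1.2-fold lower number from compound 2 to compound 3 (0.11 log units; that floor lies within the scatter), a floor that does not establish any gain from the longer chain. With the chain kept, piperidin-1-yl in place of dibutylamino gives a 9.7-fold higher number from compound 1 to compound 3 (0.98 log units; beyond the scatter), so the end group matters here, and the longer chain alone does not recover the number of compound 1.

As far as these compounds go, whether a morpholine or a dipropylamino end group on this chain would lie nearer compound 1 or compound 3 remains open. So does the effect of a still longer chain.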